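A few compounds are considered here, and "the series" means these few. Any claim that something is new, unique, unknown or untested is made for them only; others in the source may bear on it.

Compound 2 `CCOC(=O)CCCCCOc1cccc(CN(C(=O)c2ccc(-c3cccc(OCC)c3)cc2)C(C)C)c1` was tested in an ADME assay on HepG2 cells (Homo sapiens) for cytotoxicity, read by CellTiter-Glo and resazurin assay, with a stated time of 72 h; on this read-out higher numbers stand for an effect only at larger amounts of compound and lower numbers for an effect already at smaller amounts. In this assay compound 2 gives only a limit, > 22300 nM, not a number. Its neighbour compound 1 `CCOC(=O)CCCCCOc1cccc(CN(C(=O)c2ccc(-c3cnc(OC)nc3OC)cc2)C(C)C)c1` also gives only a limit in this assay, > 26000 nM. Among the measured compounds shown here, the one measured step, a step that the two limits leave unreadable from compound 1 to compound 2, cannot be read as a size because both of its ends sit at a limit, namely the limit of > 26000 nM in this assay, at which 1 of the 2 values shown sits, and (the limit of > 22300 nM in this assay, at which 1 of the 2 values shown sits).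

Compound 3 `CCOC(=O)CCCCCOc1cccc(CN(C(=O)c2ccc(-c3cccc(O)c3)cc2)C(C)C)c1` differs from compound 2 in one place: hydrogen in place of ethyl on an oxygen on an aromatic ring. No measured step bears directly on this change, and the single step shown is unreadable. Compound 3 is therefore expected to stay in the same region as compound 2, and the step to it in this assay is estimated as a step that the limit leaves unreadable from compound 2 to compound 3, no real change. The expected value for compound 3 in this assay is 30000 nM, with a range from 15000 nM to 60000 nM, most likely again reported only as a limit.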

Compound 3, half-maximal effective concentration: > 26000 nM
Compound 3: a limit, no number (the forecaster's own chance of this, stated with the estimate: 75%); the middle value lies beyond the limit too.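

Compound 3, like compound 1 and compound 2, gives only a limit in this assay, not a number, so no step among these compounds can be read. The compounds shown leave open whether hydrogen in place of ethyl changes the half-maximal effective concentration at all.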